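Compound 1 to compound 4: nitro in place of fluoro

The compounds below may be only part of what the source reports. "The series", "measured", "known", "first", "only" and "open" are said of these compounds alone.

In a functional assay on NCI-H460 cells (Homo sapiens) for antiproliferative activity, read by MTT assay, with a stated time of 24 h (a higher number here means a weaker inhibitor, a lower number a stronger inhibitor), compound 1 `Cc1cc(=O)n2nc(SCc3ccc(F)cc3)nc2[nH]1` gives > 80000 nM, which is a limit and not a number. Compound 3 `Cc1cc(O)n2nc(SCc3cccc(Cl)c3)nc2n1` gives > 80000 nM, which is also a limit. Going by the values given here, compound 2 `Cc1ccc(CSc2nc3[nH]c(C)cc(=O)n3n2)cc1` gives 49900 nM, the only actual number so far. The series therefore sits largely at the limit of > 80000 nM in this assay, at which 2 of the 3 values shown sit, and compound 1 has no exact position on the scale.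

Compound 4 `Cc1cc(=O)n2nc(SCc3ccc([N+](=O)[O-])cc3)nc2[nH]1` has not yet been measured. It differs from compound 1 as follows: nitro in place of fluoro on an aromatic carbon. This is nitro in place of fluoro on an aromatic carbon, para to a large group.

Among the compounds with values here, one measured step bears on this change: an at least 1.6-fold lower number from compound 1 to compound 2 (0.20 log units; that floor lies within the scatter), with methyl in place of fluoro on an aromatic carbon. That floor lies within the scatter, and the entering group is a different one, so the guidance is weak. No step beyond the scatter is expected in this assay, and a reading at the limit remains quite possible. The direction is left open by the data, although compound 2 at 49900 nM allows for an exact number for compound 4.

The estimate corresponds to an at least 1.3-fold lower number from compound 1 to compound 4 (0.12 log units; that floor lies within the scatter), an expected step within the scatter. Compound 4 is estimated at 60000 nM, with an expected range of 25000 nM to 80000 nM.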

Compound 4, half-maximal inhibitory concentration: > 80000 nM
Compound 4 was reported as a limit; the forecaster's own chance of this, stated with the estimate: 55%; middle value at least 1.3-fold (0.12 log units) from the limit.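

In this assay compound 4 gives a limit and not a number, as compound 1 does, so the step between these two cannot be read and nitro in place of fluoro, para to a large group, yields no exact value. Nitro in place of methyl on an aromatic carbon gives an at least 1.6-fold higher number from compound 2 to compound 4 (0.20 log units; that floor lies within the scatter), a floor only, which leaves the true size of that step unknown and does not set the two apart beyond the scatter. The change therefore adds one more reading at the end of the scale rather than a second exact number, and the series now rests mostly there: the limit of > 80000 nM in this assay, at which 3 of the 4 values shown sit.

Compound 2 at 49900 nM remains the only exact number, and the compounds shown leave open whether an amine, a methoxy group or a carboxylic acid on this aromatic carbon would give a number clearly apart from it. Also open, from the compounds shown here alone, is whether a change elsewhere on the core of compound 1, such as a longer chain in place of its methyl, would bring the series off the limit.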